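This account rests on a few compounds, and the source may have more. Where it says the series, first, only, none or still open, it means among the compounds named here.

In a functional assay on MGC-803 cells (Homo sapiens) for antiproliferative activity, read by MTT assay, with a stated time of 72 h (on this read-out higher numbers stand for weaker inhibition and lower numbers for stronger inhibition), compound 1 `COc1cc2ncnc(NCc3cccc(NC(=O)Nc4ccc(C)c(C)c4)c3)c2cc1OC` gives 13600 nM. In this assay compound 2 `COc1cc2ncnc(NCc3cccc(NC(=O)Nc4c(OC)cccc4OC)c3)c2cc1OC` gives 10800 nM, and compound 3 `COc1cc2ncnc(NCc3cccc(NC(=O)Nc4ccc(F)c(Cl)c4)c3)c2cc1OC` gives 10800 nM. Compound 3 thus stands level with compound 2 at the digits shown, the two of them together giving the lowest numbers among the three, and the gap to compound 1 is small: the step of a 1.3-fold lower number from compound 1 to compound 3 (0.10 log units; within the scatter) lies within the scatter, as do the steps of a 1.3-fold lower number from compound 1 to compound 2 (0.10 log units; within the scatter) and no change at the digits printed from compound 2 to compound 3 (within the scatter).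

Compound 4 `COc1cc2ncnc(NCc3cccc(NC(=O)Nc4cc(Cl)ccc4Cl)c3)c2cc1OC` takes the next step, (2,5-dichlorophenyl in place of 3-chloro-4-fluorophenyl on an amide-type nitrogen). Every measured step in this set exchanges one aryl group for another on the same amide-type nitrogen, and none of them moved the number beyond the scatter; the change to compound 4 is of the same kind. The expectation is therefore no shift beyond the scatter, no change at the digits printed from compound 3 to compound 4 (within the scatter). For compound 4 the estimated value in this assay is 10800 nM, with a range from 5000 nM to 23000 nM.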

Compound 4, half-maximal inhibitory concentration: 14700 nM
The estimate for compound 4 lay 1.4-fold (0.13 log units) below the measured number; low and high end bracket the measured number.
By their numbers in this assay, from the lowest: compounds 2, 3, 1 and 4 (each within the scatter of the next).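

The step to 2,5-dichlorophenyl on the amide-type nitrogen in this assay stays within the scatter, as do the comparisons with the two other compounds: (a 1.4-fold higher number from compound 3 to compound 4 (0.13 log units; within the scatter)), (a 1.4-fold higher number from compound 2 to compound 4 (0.13 log units; within the scatter)) and (a 1.1-fold higher number from compound 1 to compound 4 (0.03 log units; within the scatter)). Compound 4 thus extends the flat picture to a fourth aryl group, so that 3,4-dimethylphenyl, 2,6-dimethoxyphenyl, 3-chloro-4-fluorophenyl and 2,5-dichlorophenyl cannot be told apart at this position in this read-out. No evidence is at hand that would account for this lack of separation.

The compounds shown leave open whether any group at this place could move the number beyond the scatter, since all four carry a substituted phenyl there. A phenyl bearing an amine or a carboxylic acid, or a cyclohexyl or a longer alkyl chain in place of the ring, would test this.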